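This account rests on a few compounds, and the source may have more. Where it says the series, first, only, none or still open, it means among the compounds named here.

Measured so far in a functional assay on MCF7 cells (Homo sapiens) for antiproliferative activity, read by MTT assay, with a stated time of 48 h; on this read-out lower numbers stand for stronger inhibition and higher numbers for weaker inhibition:

- compound 1 `COc1ccc2nc(NC(c3cn(-c4ccccc4)nc3-c3ccccc3)c3c(O)ccc4ccccc34)sc2c1`: 40800 nM
- compound 2 `O=[N+]([O-])c1cccc(-c2nn(-c3ccccc3)cc2C(Nc2nc3ccc(Cl)cc3s2)c2c(O)ccc3ccccc23)c1`: 19700 nM
- compound 3 `Oc1ccc2ccccc2c1C(Nc1nc2ccc(Cl)cc2s1)c1cn(-c2ccccc2)nc1-c1ccc(Cl)cc1`: 27500 nM

Compound 3, at 27500 nM, lies within the usual scatter of both compound 2 and compound 1, so no firm order can be read between it and either of them. Compound 4 `Oc1ccc2ccccc2c1C(Nc1nc2ccc(Cl)cc2s1)c1cn(-c2ccccc2)nc1-c1ccccc1` has not yet been measured. It differs from compound 3 in one place: hydrogen in place of chloro on an aromatic carbon. This is hydrogen in place of chloro on an aromatic carbon, which turns 4-chlorophenyl into phenyl.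

One measured step changes the same group: a 1.4-fold higher number from compound 2 to compound 3 (0.14 log units; within the scatter), with 4-chlorophenyl in place of 3-nitrophenyl. Within the data shown here, that step stayed within the scatter, but it is only a single example. Compound 1 also carries a phenyl group there and gives 40800 nM, but its core differs as well, so it offers no clean comparison.

Nothing measured therefore points to a clear shift in either direction in this assay. The expected change, a 1.0-fold higher number from compound 3 to compound 4 (0.01 log units; within the scatter), is estimated to stay within the scatter. For compound 4 the estimated value is 28000 nM, with an expected range from 14000 nM to 55000 nM.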

Compound 4, half-maximal inhibitory concentration: 36300 nM
Compound 4: middle estimate off by 1.3-fold (0.11 log units), on the low side, and the stated range covers the measured number.
By their numbers in this assay, from the lowest: compounds 2, 3, 4 and 1 (each within the scatter of the next, the first and the last beyond it).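

In this assay the para chloro of the 4-chlorophenyl group can be swapped for hydrogen without leaving the scatter (a 1.3-fold higher number from compound 3 to compound 4 (0.12 log units; within the scatter)), and the same holds when hydrogen replaces the nitro of the 3-nitrophenyl group (a 1.8-fold higher number from compound 2 to compound 4 (0.27 log units; within the scatter)), so plain phenyl is now directly compared with both substituted rings and no clear shift appears. Compound 4 also supplies the one-place partner that compound 1 lacked: chloro in place of methoxy on an aromatic carbon of the shared core stays within the scatter as well (a 1.1-fold lower number from compound 1 to compound 4 (0.05 log units; within the scatter)). No independent measurement is available to explain why these swaps leave the numbers so close.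

Chloro, nitro and hydrogen are only a small sample of what this phenyl ring could carry, so it remains open whether a group of another kind, such as an amine or a carboxylic acid, would move the number beyond the scatter. These comparisons also come from a single cell line, and they cannot say whether the same changes would matter as little in any other test.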